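Aryl replacement on the enol side chain: thiazolyl analogue

The source may hold more compounds than are shown below. What is called first, only, known or untested is meant among the compounds shown, and "the series" means these compounds.

Measured in a functional assay on KB cells (Homo sapiens) for cytotoxicity (a lower number here means that less compound is needed, a higher number that more compound is needed for the effect), so far:
- compound 1 `COC1=C(C)C(=O)/C(=C(O)/C=C/c2ccc(Br)cc2)C(=O)C1(C)C` gives 1.9 ug/mL
- compound 2 `COC1=C(C)C(=O)/C(=C(O)/C=C/c2ccccc2OC)C(=O)C1(C)C` gives 2.8 ug/mL
- compound 3 `C=Cc1ccccc1/C=C/C(O)=C1/C(=O)C(C)=C(OC)C(C)(C)C1=O` gives 1.1 ug/mL

Compound 1 stands second highest of the three numbers. Its nearest neighbour is compound 2, with a 1.5-fold higher number from compound 1 to compound 2 (0.17 log units; within the scatter); the furthest is compound 3, with a 1.7-fold lower number from compound 1 to compound 3 (0.24 log units; within the scatter). Among the compounds with values here, the only step beyond the scatter is a 2.5-fold lower number from compound 2 to compound 3 (0.41 log units; beyond the scatter).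

Compound 4 `COC1=C(C)C(=O)/C(=C(O)/C=C/c2nccs2)C(=O)C1(C)C` differs from compound 1 as follows: 1,3-thiazol-2-yl in place of 4-bromophenyl on a double-bonded chain carbon bound to a double-bonded chain carbon

Both measured steps that swap the aryl group on this chain carbon stay within the scatter, so the group in this position has so far moved the number little. Within the data shown here, no measured step introduces a heteroaromatic ring here, so the effect of the 1,3-thiazol-2-yl group is untested. Compound 4 is therefore expected to land close to compound 1, with the step of a 1.3-fold higher number from compound 1 to compound 4 (0.12 log units; within the scatter) not clearly beyond the scatter. The estimate for compound 4 in this assay is 2.5 ug/mL, with a range from 1 ug/mL to 6 ug/mL.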

Compound 4, concentration for half-maximal effect: 3 ug/mL
For compound 4 the middle estimate is 1.2-fold (0.08 log units) below the measured one; measured number inside the range.
By their numbers in this assay, from the lowest: compounds 3, 1, 2 and 4 (each within the scatter of the next, the first and the last beyond it).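

In this assay this chain carbon accepts a five-membered aromatic ring with hetero atoms in place of a six-membered carbon ring without a step beyond the scatter: a 1.6-fold higher number from compound 1 to compound 4 (0.20 log units; within the scatter) and a 1.1-fold higher number from compound 2 to compound 4 (0.03 log units; within the scatter) leave 1,3-thiazol-2-yl indistinguishable from 4-bromophenyl and 2-methoxyphenyl. Only 2-vinylphenyl separates from the new group, with a 2.7-fold higher number from compound 3 to compound 4 (0.44 log units; beyond the scatter) as a modest step, so compound 3 now stands apart from both compound 2 and compound 4 but not from compound 1. No supporting data bear on these differences.

Still open, on these data alone, is how a pyridyl, furanyl or saturated cyclohexyl group would behave on this chain carbon. As far as these compounds go, the four compounds also share one core, so the effect of an amine or a carboxylic acid placed elsewhere on it remains unknown.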